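A few compounds are considered here, and "the series" means these few. Any claim that something is new, unique, unknown or untested is made for them only; others in the source may bear on it.

In a functional assay on HT-29 cells (Homo sapiens) for inhibition, read by CCK-8 assay, with a stated time of 24 h (a higher number here means a weaker inhibitor, a lower number a stronger inhibitor), compound 1 `Cc1cccc(-n2cc(-c3ccc(/C=C4\C(=O)Nc5ccccc54)cc3)nn2)c1` gives 3940 nM. Compound 2 `O=C1Nc2ccccc2/C1=C/c1ccc(-c2cn(-c3cccc(F)c3)nn2)cc1` reads > 20000 nM, which is a limit of the assay and not a number. Compound 3 `O=C1Nc2ccccc2/C1=C/c1ccc(-c2cn(-c3ccc(Cl)cc3)nn2)cc1` differs from compound 2 by 4-chlorophenyl in place of 3-fluorophenyl on an aromatic nitrogen, with 4-chlorophenyl in place of 3-fluorophenyl on an aromatic nitrogen. Within the data shown here, one measured step bears on this: an at least 5.0-fold higher number from compound 1 to compound 2 (0.70 log units; beyond the scatter), with fluoro in place of methyl on an aromatic carbon of that same aryl group. A change of similar size is therefore expected in this assay, towards a lower number. The expected step is an at least 2.5-fold lower number from compound 2 to compound 3 (0.39 log units; beyond the scatter). For compound 3 the estimated value is 8000 nM, with an expected range of 2000 nM to 25000 nM.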

Compound 3, half-maximal inhibitory concentration: 14000 nM
For compound 3 the middle estimate is 1.8-fold (0.24 log units) below the measured one; measured number inside the range.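

Compound 2 holds only a limit of the assay: the limit of > 20000 nM in this assay, at which 1 of the 3 values shown sits.

With 4-chlorophenyl on the aromatic nitrogen, this assay shows an at least 1.4-fold lower number from compound 2 to compound 3 (0.15 log units; that floor lies within the scatter), which gives no firm gain over 3-fluorophenyl. The 3-methylphenyl group stays ahead of 4-chlorophenyl, with a 3.6-fold higher number from compound 1 to compound 3 (0.55 log units; beyond the scatter), so both halogen-bearing compounds read weaker than the methyl compound.

Compound 3 differs from compound 1 in both the group and its place on the phenyl ring, and these two changes cannot be separated here. From the compounds shown here alone, how a methoxy group or an amine on that phenyl ring would read stays open.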